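Aryl swaps at the benzylic position of the shared core

The source may hold more compounds than are shown below. What is called first, only, known or untested is meant among the compounds shown, and "the series" means these compounds.

Among the measured compounds shown here, compound 3 `Cc1cc(Cc2cccs2)c(=O)n(CC(=O)Nc2ccc(Br)cc2)n1` holds the only number among the three values so far: in an assay on HL-60 cells for agonist activity at N-formyl peptide receptor 3 (Homo sapiens), read by calcium flux (a higher number here means that more compound is needed for the effect, a lower number that less compound is needed), compound 3 gives 10200 nM. Compound 1 `Cc1cc(Cc2cccc(F)c2)c(=O)n(CC(=O)Nc2ccc(Br)cc2)n1` reaches only a limit of this assay, giving > 50000 nM. Compound 2 `Cc1cc(Cc2ccc(C(F)(F)F)cc2)c(=O)n(CC(=O)Nc2ccc(Br)cc2)n1` likewise gives only a limit, > 50000 nM. Compound 4 `Cc1cc(Cc2ccc(C#N)cc2)c(=O)n(CC(=O)Nc2ccc(Br)cc2)n1` is not yet measured; it differs from compound 3 in that (4-cyanophenyl in place of thiophen-2-yl on a saturated chain carbon bound to an aromatic carbon). For the measured compounds named here, the steps that bear on this are an at least 4.9-fold lower number from compound 1 to compound 3 (0.69 log units; beyond the scatter) and an at least 4.9-fold lower number from compound 2 to compound 3 (0.69 log units; beyond the scatter), each moving from a phenyl variant to thiophen-2-yl; compound 4 reverses that direction. A return toward the limit of > 50000 nM in this assay, at which 2 of the 3 values shown sit, is therefore expected, with a 3.9-fold higher number from compound 3 to compound 4 (0.59 log units; beyond the scatter). Compound 4 is expected at 40000 nM, within 10000 nM to 150000 nM.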

Compound 4, half-maximal effective concentration: > 50000 nM
Compound 4 gave a limit, no number; the forecaster's own chance of this, stated with the estimate: 55%; middle value at least 1.2-fold (0.09 log units) from the limit.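

In this assay, 4-cyanophenyl in place of thiophen-2-yl brings an at least 4.9-fold higher number from compound 3 to compound 4 (0.69 log units; beyond the scatter). With a nitrile as the substituent, the benzylic aryl series again ends at a limit rather than a number, leaving thiophen-2-yl as the only group shown at this place that gives a number: the limit of > 50000 nM in this assay, at which 3 of the 4 values shown sit. The steps among compound 1, compound 2 and compound 4 cannot be read, so these three cannot be ranked.

Going by these compounds, whether furan-2-yl or thiophen-3-yl would also give a number at this place remains open. Unsubstituted phenyl is equally open, so the substituents cannot be separated from the six-membered ring itself.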